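The source may report more compounds than this note shows. Statements on the series, on what has been measured and on what is new or still open speak of the compounds shown alone.

Measured so far:
Compound 1, `CC(=O)N[C@@H]1CCC[C@H](C(=O)Nc2cc(-c3cnn4c3CCCC4)c(F)cn2)C1`: 73 uL/min
Compound 2, `CC(=O)N[C@@H]1CCC[C@H](C(=O)Nc2cc(-c3cnn4c3CCC4)c(Cl)cn2)C1`: 72 uL/min

In an ADME assay on cells (Hepatocyte, Rattus norvegicus) for metabolic stability, using equilibrium dialysis (a higher number here means faster removal of the compound, a lower number slower removal), compound 2 gives 72 uL/min, and in the same assay compound 1 gives 73 uL/min; these two values lie within the usual scatter of each other, so neither stands apart. Compound 3, `CC(=O)N[C@@H]1CCC[C@H](C(=O)Nc2cc(-c3cnn4c3CN(C)CC4)c(Cl)cn2)C1`, has not yet been measured. It differs from compound 2 in one place: a group of 10 heavy atoms (7 carbon, 3 nitrogen; one five-membered aromatic ring with 2 hetero atoms, one six-membered non-aromatic ring with 2 hetero atoms) in place of a group of 8 heavy atoms (6 carbon, 2 nitrogen; one five-membered non-aromatic ring with 1 hetero atom, one five-membered aromatic ring with 2 hetero atoms), on an aromatic carbon. Among the compounds with values here, no measured pair shows what such a change does here, so the expectation rests on compound 2 alone. Compound 3 is expected to sit close to compound 2, with a small step of a 1.2-fold lower number from compound 2 to compound 3 (0.08 log units; within the scatter) that stays within the scatter. The estimate for compound 3 is 60 uL/min, with a range from 25 uL/min to 140 uL/min.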

Compound 3, intrinsic clearance in a liver preparation (reported as CLH), per the amount of preparation that the assay uses: 7.7 uL/min
For compound 3 the middle estimate is 7.8-fold (0.89 log units) above the measured one; measured number below the stated range.
By their numbers in this assay, from the lowest: compound 3; then compounds 2 and 1 (each within the scatter of the next).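

In this assay the change on the aromatic carbon opposite the ring nitrogen gives a 9.4-fold lower number from compound 2 to compound 3 (0.97 log units; beyond the scatter), so this position can clearly alter how fast a compound is removed. The entering group has a six-membered non-aromatic ring with 2 hetero atoms, where the leaving group has a five-membered non-aromatic ring with 1 hetero atom. No measurement here explains the drop. Ring size and the added nitrogen change together, so the compounds shown cannot separate them. Going by these compounds, how a ring with an oxygen atom in place of that nitrogen would behave also stays open.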